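A few compounds are considered here, and "the series" means these few. Any claim that something is new, unique, unknown or untested is made for them only; others in the source may bear on it.

Three compounds sharing one core were tested in a functional assay on HCT-116 cells (Homo sapiens) for antiproliferative activity, read by CCK-8 assay, with a stated time of 72 h, tested at 2 uM; on this read-out higher numbers stand for a stronger effect at the one concentration tested and lower numbers for a weaker effect. Compound 3 `CC(C)n1cnc2c(Nc3cccc(Cl)c3)nc(NCOCc3ccc(/C=C/C(=O)Nc4ccccc4N)cc3)nc21` gives 18.5%. Compound 1 `CCCCn1cnc2c(Nc3cccc(Cl)c3)nc(NCOCc3ccc(/C=C/C(=O)Nc4ccccc4N)cc3)nc21` gives 4.76%, and compound 2 `CC(C)n1cnc2c(Nc3ccccc3)nc(NCOCc3ccc(/C=C/C(=O)Nc4ccccc4N)cc3)nc21` gives 2.53%; the values of compound 1 and compound 2 lie within the scatter of each other. The cores of compound 3 and compound 2 differ by hydrogen in place of chloro on an aromatic carbon, and the step of a number 16 percentage points higher from compound 2 to compound 3 (beyond the scatter). Compound 3 and compound 1 differ by butyl in place of isopropyl on an aromatic nitrogen, and the step of a number 13.7 percentage points lower from compound 3 to compound 1 (beyond the scatter). Compound 4 `CCCCn1cnc2c(Nc3ccccc3)nc(NCOCc3ccc(/C=C/C(=O)Nc4ccccc4N)cc3)nc21` has not yet been measured. It differs from compound 2 by butyl in place of isopropyl on an aromatic nitrogen, the same change at the same place as from compound 3 to compound 1. The step from compound 2 to compound 4 is expected to be a number 1.5 percentage points lower from compound 2 to compound 4 (within the scatter), smaller than the earlier one. This rests on compound 2 standing at 2.53%, which leaves little room for a further fall. Compound 4 is therefore estimated at 1% in this assay, between -5% and 8%.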

Compound 4, a percentage reported as inhibition, at one concentration (the size of the read-out at that concentration, not a potency): 6.58%
The estimate for compound 4 lay 5.6 percentage points below the measured number, and the stated range covers the measured number.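

In this assay, butyl in place of isopropyl on an aromatic nitrogen does not carry over from the core with chloro to the core without it, the step here being a number 4.1 percentage points higher from compound 2 to compound 4 (within the scatter): the same change on two cores in this assay, a number 13.7 percentage points lower (beyond the scatter) from compound 3 to compound 1 and a number 4.1 percentage points higher (within the scatter) from compound 2 to compound 4, 17.8 percentage points apart, beyond the scatter of two such steps. Hydrogen in place of chloro on an aromatic carbon, at a number 1.8 percentage points higher from compound 1 to compound 4 (within the scatter), likewise differs from its size on the isopropyl core: the same change on two cores in this assay, a number 16 percentage points higher (beyond the scatter) from compound 2 to compound 3 and a number 1.8 percentage points lower (within the scatter) from compound 4 to compound 1, 17.8 percentage points apart, beyond the scatter of two such steps. So across these four compounds each change depends on the group present at the other place, which means a step measured on one core cannot be transferred to the other, but the data do not show why.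

The compounds shown leave open how a longer chain such as hexyl on that nitrogen would behave. They also leave open whether fluoro or methoxy in place of chloro would give a step like that of chloro.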